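Hexyl in place of isopropyl on the aryl urea

The compounds below may be only part of what the source reports. "The series", "measured", "known", "first", "only" and "open" are said of these compounds alone.

Measured so far in an ADME assay on the whole organism with Oryza sativa as the target, tested at 10 uM; a higher number here means a weaker effect of the compound at the concentration tested, a lower number a stronger effect:
compound 1, `Cc1cccc(NC(=O)N[C@H](C)c2ccccc2)c1`, gives 47%
compound 2, `CC(C)c1ccc(NC(=O)N[C@H](C)c2ccccc2)cc1`, gives 49%
compound 3, `CC(C)c1ccc(NC(=O)N[C@@H](C)c2ccccc2)cc1`, gives 86%

Compound 2 stands second highest of the three numbers. Its nearest neighbour is compound 1, whose value lies within the scatter of that of compound 2; the furthest is compound 3. The only step shown between compounds that differ in one place is a number 37 percentage points higher from compound 2 to compound 3 (beyond the scatter), and it rests on (the fact that compounds 2 and 3 differ only in the configuration as drawn), a change of configuration alone.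

The unmeasured compound 4, `CCCCCCc1ccc(NC(=O)N[C@H](C)c2ccccc2)cc1`, differs from compound 2 by hexyl in place of isopropyl on an aromatic carbon. Among the compounds with values here, no measured step changes a group on this ring in this way; the measured step concerns configuration, not the substituent, so it does not bear on the new change. Compound 1 and compound 2 carry different groups at different places, and their two values are within the scatter of each other, which gives no sign of a substituent effect. The expected step is therefore a number 1 percentage points higher from compound 2 to compound 4 (within the scatter), none beyond the scatter. Compound 4 is expected to give 50%, between 30% and 72% in this assay.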

Compound 4, a percentage reported as activity, at one concentration (the size of the read-out at that concentration, not a potency): 101%
Estimate against measurement, compound 4: 51 percentage points below, and the stated range ends below it.
By their numbers in this assay, from the lowest: compounds 1 and 2 (each within the scatter of the next); then compound 3; then compound 4.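

In this assay, hexyl in place of isopropyl on this aromatic carbon gives a number 52 percentage points higher from compound 2 to compound 4 (beyond the scatter), so here the longer chain goes with a weaker effect at the concentration tested. The earlier compounds shown here showed a step beyond the scatter only for a change of configuration; this one shows that a change of group at this place, with the configuration as drawn kept the same, can matter just as much. Nothing measured here accounts for the size of this step.

On these data alone, with only isopropyl and hexyl compared at this place, it stays open whether the number climbs gradually with chain length or jumps, which a butyl chain could help to settle, and whether an amine or a carboxylic acid there would behave like hexyl. Also open, as far as these compounds go, is how hexyl behaves in the opposite configuration.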